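Cytotoxicity readings for three compounds and one prediction

A few compounds are considered here, and "the series" means these few. Any claim that something is new, unique, unknown or untested is made for them only; others in the source may bear on it.

Measured compounds:
compound 1 `CN(C)c1ccc(/C=C2\CCC/C(=C\c3cccc([N+](=O)[O-])c3)C2=O)cc1` gives > 400000 nM, a limit of the assay.
compound 2 `Cc1ccc(/C=C2\CCC/C(=C\c3cccc([N+](=O)[O-])c3)C2=O)cc1` gives 192000 nM.
compound 3 `CN(C)c1ccc(/C=C2\CCC/C(=C\c3ccc([N+](=O)[O-])cc3)C2=O)cc1` gives > 400000 nM, a limit of the assay.

All three were tested in an ADME assay on HPC cells (Homo sapiens) for cytotoxicity, with a stated time of 24 h; a higher number here means that more compound is tolerated, a lower number that less compound is tolerated. Compound 1 reached only the limit > 400000 nM in this assay. Compound 2 gave a numerical reading of 192000 nM. Compound 3 also stopped at the limit > 400000 nM.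

The change from compound 1 to compound 2 is methyl in place of dimethylamino on an aromatic carbon, and it produced an at least 2.0-fold lower number from compound 1 to compound 2 (0.31 log units; beyond the scatter). Compound 3 differs from compound 1 in its core: 4-nitrophenyl in place of 3-nitrophenyl on a double-bonded chain carbon bound to a double-bonded ring carbon. The step that the two limits leave unreadable from compound 1 to compound 3 stays unreadable, since both values sit at the limit of > 400000 nM in this assay, at which 2 of the 3 values shown sit.

Compound 4 `Cc1ccc(/C=C2\CCC/C(=C\c3ccc([N+](=O)[O-])cc3)C2=O)cc1` has not been measured. It differs from compound 3 by methyl in place of dimethylamino on an aromatic carbon, the same change as that from compound 1 to compound 2. A comparable drop is expected, an at least 2.0-fold lower number from compound 3 to compound 4 (0.30 log units; that floor lies within the scatter), resting on the earlier step of an at least 2.0-fold lower number from compound 1 to compound 2 (0.31 log units; beyond the scatter). The starting point is uncertain, because compound 3 itself sits at the limit > 400000 nM. For compound 4 the expected value is 200000 nM, likely between 80000 nM and 400000 nM.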

Compound 4, half-maximal cytotoxic concentration: 92000 nM
Beside the measured number, compound 4's estimate is 2.2-fold (0.34 log units) above it; the measured number falls inside the stated range.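

In this assay, methyl in place of dimethylamino on an aromatic carbon lowers the number on the second core too, with an at least 4.3-fold lower number from compound 3 to compound 4 (0.63 log units; beyond the scatter). Set beside the earlier step, the direction of the change carries from one core to the other in the two pairs shown, but this does not show that its size carries as well: the same change on two cores in this assay, an at least 2.0-fold lower number (0.31 log units; beyond the scatter) from compound 1 to compound 2 and an at least 4.3-fold lower number (0.63 log units; beyond the scatter) from compound 3 to compound 4; the limit leaves it open whether they differ
Both steps start from a limit and not from a number, so each gives only the smallest size the step can have: the limit of > 400000 nM in this assay, at which 2 of the 4 values shown sit.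

The compounds shown leave open whether other groups in the same place, such as methoxy, chlorine or a carboxylic acid, would give a lower number in this assay as methyl does. They also leave open whether the change would run the same way on a core in which an amine stands where the nitro group stands here, as only two cores are shown.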